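Replacing Isopropoxy with Cyano in a Carbinol Series

The source may hold more compounds than are shown below. What is called first, only, known or untested is meant among the compounds shown, and "the series" means these compounds.

The set concerns four carbinols tested in an ADME assay on L6 cells (Rattus norvegicus) for cytotoxicity, read by resazurin assay, with a stated time of 72 h; a higher number here means a weaker inhibitor, a lower number a stronger inhibitor. Compound 1 `CC(C)Oc1ccc(C(O)(c2ccc(C(F)(F)F)cc2)c2cccnc2)cc1` gives 47600 nM. Compound 2 `N#Cc1ccc(C(O)(c2ccc(C(F)(F)F)cc2)c2cccnc2)cc1` carries cyano in place of isopropoxy on an aromatic carbon and gives 76500 nM, so the step of a 1.6-fold higher number from compound 1 to compound 2 (0.21 log units; within the scatter) is small. Compound 3 `CC(C)Oc1ccc(C(O)(c2ccc(Cl)cc2)c2cccnc2)c(F)c1` gives 58200 nM; its value and those of compound 1 and compound 2 all lie within the scatter of one another, so no order among the three can be read from them. The difference between the core of compound 3 and the core of compound 1 is not broken down here.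

Compound 4 `N#Cc1ccc(C(O)(c2ccc(Cl)cc2)c2cccnc2)c(F)c1` has not yet been measured in this assay. It carries cyano in place of isopropoxy on an aromatic carbon. The surroundings differ from the earlier pair in that the site is meta to a fluoro group, so this is the same kind of change rather than the same one. Since the earlier step was within the scatter, a comparably small step is expected, a 1.5-fold higher number from compound 3 to compound 4 (0.16 log units; within the scatter). This expectation rests on the measured step of a 1.6-fold higher number from compound 1 to compound 2 (0.21 log units; within the scatter). Compound 4 is thus estimated to give 85000 nM, with a likely range from 45000 nM to 160000 nM.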

Compound 4, half-maximal inhibitory concentration: > 100000 nM
Compound 4: no number, only a limit; the forecaster's own chance of this, stated with the estimate: 20%; at least 1.1-fold (0.07 log units) between middle value and limit.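

In this assay compound 4 gives > 100000 nM, which is a limit of the assay and not a number. Set against compound 3, this yields only a floor for the step, an at least 1.7-fold higher number from compound 3 to compound 4 (0.23 log units; that floor lies within the scatter), so the true size of the change on this core remains unknown, and the floor itself does not stand beyond the scatter. The result therefore shows that replacing isopropoxy with cyano can be compared on two cores, but it does not show that the change carries over with the same size, or that it differs between them: the same change on two cores in this assay, a 1.6-fold higher number (0.21 log units; within the scatter) from compound 1 to compound 2 and an at least 1.7-fold higher number (0.23 log units; that floor lies within the scatter) from compound 3 to compound 4; the limit leaves it open whether they differ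

The compounds shown leave open how an amine or a carboxylic acid in place of isopropoxy would read in this assay. Also open, on these data alone, is how much the difference between the core of compound 1 and the core of compound 3 contributes on its own, as no single-place comparison here separates it.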